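Chain extension to the hydroxamate: notes on compound 4

The source may hold more compounds than are shown below. What is called first, only, known or untested is meant among the compounds shown, and "the series" means these compounds.

Measured so far:
compound 1, `COc1cc2c(Oc3ccc(NC(=O)c4nn(-c5ccccc5C)cc(C)c4=O)cc3)ccnc2cc1OCCCC(=O)NO`, 1600 nM
compound 2, `COc1cc2c(Oc3ccc(NC(=O)c4nn(-c5ccccc5C)ccc4=O)cc3)ccnc2cc1OCCCCCC(=O)NO`, 4360 nM
compound 3, `COc1cc2c(Oc3ccc(NC(=O)c4nn(-c5ccccc5C)cc(C)c4=O)cc3F)ccnc2cc1OCCCC(=O)NO`, 2600 nM
Not yet measured: compound 4, `COc1cc2c(Oc3ccc(NC(=O)c4nn(-c5ccccc5C)cc(C)c4=O)cc3)ccnc2cc1OCCCCCCC(=O)NO`

In a functional assay on MCF7 cells (Homo sapiens) for inhibition, read by MTT assay, with a stated time of 72 h (on this read-out lower numbers stand for stronger inhibition and higher numbers for weaker inhibition), compound 1 gives 1600 nM, the lowest number shown; compound 3 sits nearest, the step of a 1.6-fold higher number from compound 1 to compound 3 (0.21 log units; within the scatter), and compound 2 sits furthest, beyond the scatter. Compound 4 differs from compound 1 by 3-(hydroxycarbamoyl)propyl in place of hydroxycarbamoyl on a saturated chain carbon, three bonds along the chain from an oxygen on an aromatic ring. Among the measured compounds shown here, no measured step isolates this change. For the measured compounds named here, compound 2 carries a longer chain than compound 1 but differs in one further place as well, so its two values show only that the longer-chain compound reads higher. Going by the values given here, the single clean step, a 1.6-fold higher number from compound 1 to compound 3 (0.21 log units; within the scatter), concerns another change and is within the scatter. A modest rise is therefore expected, a 1.8-fold higher number from compound 1 to compound 4 (0.24 log units; within the scatter), with wide uncertainty. Compound 4 is estimated at 2800 nM, within 1000 nM to 8000 nM.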

Compound 4, half-maximal inhibitory concentration: 1830 nM
The estimate for compound 4 lay 1.5-fold (0.18 log units) above the measured number; low and high end bracket the measured number.
By their numbers in this assay, from the lowest: compounds 1, 4, 3 and 2 (each within the scatter of the next, the first and the last beyond it).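

In this assay, among the compounds shown here, 3-(hydroxycarbamoyl)propyl in place of hydroxycarbamoyl on this saturated chain carbon gives a 1.1-fold higher number from compound 1 to compound 4 (0.06 log units; within the scatter), the only step that isolates this change. The longer chain is thus tolerated at this position, which compound 2, differing in one further place, could not show. No evidence on the origin of this result is available. Still open, going by these compounds, is whether a longer chain than 6-(hydroxycarbamoyl)hexyl keeps the number within the scatter. Also open, on these data alone, is whether a carboxylic acid can stand in place of the hydroxycarbamoyl end.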